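A few compounds are considered here, and "the series" means these few. Any claim that something is new, unique, unknown or untested is made for them only; others in the source may bear on it.

Compound 1 `CCOC(=O)CCSc1nc2ccccc2n1CC(=O)O` gives 11400 nM in an assay on HEK293 cells for displacement of a labelled ligand from prostaglandin D2 receptor 2 (Homo sapiens); a lower number here means a stronger inhibitor, a higher number a weaker inhibitor.
Compound 2 `O=C(O)Cn1c(SCc2ccc(Br)cc2)nc2ccccc21` gives 220 nM in this assay.
Compound 3 `O=C(O)Cn1c(SCc2cccc(Br)c2)nc2ccccc21` gives 370 nM in this assay.

Compound 3 stands second highest of the three numbers in this assay; its nearest neighbour is compound 2, with a 1.7-fold higher number from compound 2 to compound 3 (0.23 log units; within the scatter), and its furthest is compound 1, with a 31-fold lower number from compound 1 to compound 3 (1.49 log units; beyond the scatter). Compound 4 `COC(=O)c1cc(Br)cc(CSc2nc3ccccc3n2CC(=O)O)c1` differs from compound 3 by methoxycarbonyl in place of hydrogen on an aromatic carbon, on an aromatic carbon meta to a bromo group. Among the measured compounds shown here, none of the measured steps alters a substituent on that aromatic ring: a 52-fold lower number from compound 1 to compound 2 (1.71 log units; beyond the scatter) and a 31-fold lower number from compound 1 to compound 3 (1.49 log units; beyond the scatter) replace (ethoxycarbonyl)methyl by a bromophenyl, and a 1.7-fold higher number from compound 2 to compound 3 (0.23 log units; within the scatter) shifts only the bromo position. For the measured compounds named here, no step therefore bears directly on this change, and no step beyond the scatter is expected in this assay. Compound 4 is estimated at 300 nM (range 100 nM to 1000 nM), which would mean an expected 1.2-fold lower number from compound 3 to compound 4 (0.09 log units; within the scatter).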

Compound 4, half-maximal inhibitory concentration: 330 nM
The estimate for compound 4 lay 1.1-fold (0.04 log units) below the measured number; the measured number falls inside the stated range.
By their numbers in this assay, from the lowest: compounds 2, 4 and 3 (each within the scatter of the next); then compound 1.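

In this assay, among the compounds shown here, methoxycarbonyl in place of hydrogen on an aromatic carbon, meta to a bromo group, gives a 1.1-fold lower number from compound 3 to compound 4 (0.05 log units; within the scatter), the first change here that adds a substituent to that ring. The earlier steps shown here only moved the bromo group or replaced the whole bromophenyl, whereas this one shows that the position accepts 4 further heavy atoms with the step staying within the scatter. No supporting measurement accounts for this result. From the compounds shown here alone, whether a carboxylic acid or an amine at this carbon would behave alike remains open. So does whether methoxycarbonyl would be accepted without the bromo group.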